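Methylation of the amino group on compound 3

The source may hold more compounds than are shown below. What is called first, only, known or untested is meant among the compounds shown, and "the series" means these compounds.

Of the compounds shown here, three sharing one core have been measured in a functional assay on PHA-Ly cells (Homo sapiens); on this read-out lower numbers stand for stronger inhibition and higher numbers for weaker inhibition. Compound 1 `CNc1nc(SC)nc2c1ncn2[C@@H]1C[C@@H](O)[C@H](CO)O1` gives 81 uM, compound 2 `CN(C)c1nc(Br)nc2c1ncn2[C@@H]1C[C@@H](O)[C@H](CO)O1` gives 88 uM, and compound 3 `Nc1nc(Br)nc2c1ncn2[C@@H]1C[C@@H](O)[C@H](CO)O1` gives 1.6 uM. Compound 3 thus stands with the lowest number of the three, with both other compounds well beyond the scatter above it. Among the compounds with values here, the only single-point step among the measured compounds, a 55-fold lower number from compound 2 to compound 3 (1.74 log units; beyond the scatter), shows how much the amino group matters on this core.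

Compound 4 `CNc1nc(Br)nc2c1ncn2[C@@H]1C[C@@H](O)[C@H](CO)O1` is not yet measured. It differs from compound 3 by methyl in place of hydrogen on a nitrogen on an aromatic ring, a change that sits halfway between compound 3 and compound 2. Compound 1 also carries methylamino, but it differs from compound 3 in two places, so it only shows that its number and that of compound 3 lie far apart. Because the step from compound 2 to compound 3 was a 55-fold lower number from compound 2 to compound 3 (1.74 log units; beyond the scatter), compound 4 is expected to lose part of that gain, giving an estimated 9.4-fold higher number from compound 3 to compound 4 (0.97 log units; beyond the scatter) upward in this assay. Compound 4 is therefore estimated at 15 uM, with a range from 4 uM to 60 uM.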

Compound 4, concentration for 50% inhibition: 30 uM
Compound 4: middle estimate off by 2.0-fold (0.30 log units), on the low side, within the range that was stated.
By their numbers in this assay, from the lowest: compound 3; then compound 4; then compounds 1 and 2 (each within the scatter of the next).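

In this assay the first methyl on this nitrogen accounts for most of the loss seen with the dimethylamino group: amino to methylamino gives a 19-fold higher number from compound 3 to compound 4 (1.27 log units; beyond the scatter) while the second methyl is worth far less, as the change read the other way gives only a 2.9-fold lower number from compound 2 to compound 4 (0.47 log units; beyond the scatter) on removing it. With methylamino held constant, the group on the aromatic carbon also counts, though modestly, with a 2.7-fold lower number from compound 1 to compound 4 (0.43 log units; beyond the scatter) on going to bromo. No supporting measurement is at hand to explain why a single methyl on this nitrogen costs so much.

Going by these compounds, it remains open whether a longer chain on this nitrogen, such as ethylamino, would lower the inhibition further or no more than methylamino does. On these data alone, how chloro or methylsulfanyl on the aromatic carbon would behave alongside the unsubstituted amino group is also open.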